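Solubility limits and the step to compound 4

The source may report more compounds than this note shows. Statements on the series, on what has been measured and on what is new or still open speak of the compounds shown alone.

Compound 1 `O=C(O)c1ccc(C(=O)/C(=C\c2ccc(O)c([N+](=O)[O-])c2)SCc2ccc(Br)cc2)cc1` gives < 1000 ug/mL
Compound 2 `O=C(O)c1ccc(C(=O)/C(=C\c2ccc(Br)c([N+](=O)[O-])c2)SCc2ccc(Cl)cc2)cc1` gives < 1000 ug/mL
Compound 3 `O=C(O)c1ccc(C(=O)/C(=C\c2ccc(Br)c([N+](=O)[O-])c2)SCc2ccc(Cl)cc2Cl)cc1` gives < 1000 ug/mL

All three readings come from a physicochemical assay for solubility (on this read-out lower numbers stand for lower solubility and higher numbers for higher solubility), and each is a limit, not a number. Compound 3 stands at the limit < 1000 ug/mL and has no exact place on the scale. The whole set comes down to the limit of < 1000 ug/mL in this assay, at which 3 of the 3 values shown sit, so the compounds cannot be ranked.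

Compound 4 `O=C(O)c1ccc(C(=O)/C(=C\c2ccc(Br)c([N+](=O)[O-])c2)SCc2ccc(Br)cc2)cc1` differs from compound 3 in one place, on a saturated chain carbon bound to a sulfur: 4-bromophenyl in place of 2,4-dichlorophenyl on a saturated chain carbon bound to a sulfur, with 4-bromophenyl in place of 2,4-dichlorophenyl.

For the measured compounds named here, the only measured step on this group, a step that the two limits leave unreadable from compound 2 to compound 3, has no readable size, so no step beyond the usual scatter is expected in this assay, and no direction can be given. The expected size is a step that the limit leaves unreadable from compound 3 to compound 4 and it rests on limits alone. For compound 4 the estimate is 300 ug/mL, with an expected range from 60 ug/mL to 1000 ug/mL and another limit as the likeliest reading.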

Compound 4, solubility: < 1000 ug/mL
Compound 4: only a limit was reported (the forecaster's own chance of this, stated with the estimate: 90%); the middle value lies beyond the limit too.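

Compound 4 also gives only a limit in this assay, so no step from it to compound 1, compound 2 or compound 3 can be read: the limit of < 1000 ug/mL in this assay, at which 4 of the 4 values shown sit.

The compounds shown leave open the exact solubility of each one and whether any of these changes shifts it.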